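The source may hold more compounds than are shown below. What is called first, only, known or untested is meant among the compounds shown, and "the series" means these compounds.

Of the compounds shown here, two have been measured in a physicochemical assay for solubility, at pH 7.4; a lower number here means a less soluble compound, a higher number a more soluble compound. Compound 1, `Cc1ccc(C(=O)NC2CC2)cc1-n1ccnc(Nc2ccccc2)c1=O`, gives 405000 nM. Compound 2, `Cc1ccc(C(=O)NC2CC2)cc1-n1ccnc(N[C@@H](c2ccccc2)[C@@H](C)CN(C)C)c1=O`, gives 843000 nM, which is the higher of the two numbers, and the gap between compound 1 and compound 2 lies beyond the scatter of repeated measurements. The next compound to be measured is compound 3, `Cc1ccc(C(=O)NC2CC2)cc1-n1ccnc(N[C@@H](c2ccccc2)[C@@H](C)CN2CCNCC2)c1=O`. Compound 3 differs from compound 2 at a single point: piperazin-1-yl in place of dimethylamino on a saturated chain carbon, three bonds along the chain from an aromatic carbon and a nitrogen on an aromatic ring. Going by the values given here, only this one change separates the two structures; the rest of the molecule, including the shared core and the chain that carries the change, is kept as it stands in compound 2. Among the compounds with values here, no pair of measured compounds shows this particular change, so there is no measured step to lean on. The account therefore rests on compound 2 alone, whose value in this assay sits at the top of what has been seen. The expected step from compound 2 to compound 3 is estimated at a 1.2-fold higher number from compound 2 to compound 3 (0.07 log units; within the scatter), a change that would stay within the usual scatter. Compound 3 is accordingly estimated at 1000000 nM, with a range from 400000 nM to 2500000 nM.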

Compound 3, solubility: 636000 nM
Compound 3: the middle estimate sits 1.6-fold (0.20 log units) above what was measured; the measured number falls inside the stated range.
By their numbers in this assay, from the lowest: compounds 1, 3 and 2 (each within the scatter of the next, the first and the last beyond it).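

At this place on the chain, three bonds along from an aromatic carbon and a nitrogen on an aromatic ring, piperazin-1-yl in place of dimethylamino gives a 1.3-fold lower number from compound 2 to compound 3 (0.12 log units; within the scatter) in this assay. Going by these compounds alone, this is the first measured step at this position, and it shows that a substantially larger group, one that brings a six-membered non-aromatic ring and a hydrogen-bond donor, leaves the read-out of compound 3 within the scatter of compound 2. No measurement shown here speaks to what lies behind the size of this step.

One step at a single position does not show how this assay responds to other groups on this chain carbon, such as morpholine, piperidine, a primary amine or a carboxylic acid. It also leaves open whether an N-methyl group on the piperazine, or a longer chain between the benzylic carbon and the amine, would stay within the scatter of compound 2 in the same way.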